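Aryl Variation on the Amine Nitrogen: Cytotoxicity Notes

The source may hold more compounds than are shown below. What is called first, only, known or untested is meant among the compounds shown, and "the series" means these compounds.

The series shares one core with an aryl group on an amine nitrogen. Compound 1 `Cc1ccc(S(=O)(=O)/N=C(/CCNC2=CC(=O)c3ccccc3C2=O)Nc2ccc(Cl)cc2)cc1` carries 4-chlorophenyl there; in an ADME assay on HEK293 cells (Homo sapiens) for cytotoxicity, read by MTT assay, with a stated time of 48 h (a higher number here means a weaker inhibitor, a lower number a stronger inhibitor), compound 1 gives 65400 nM. Compound 2 `Cc1ccc(S(=O)(=O)/N=C(/CCNC2=CC(=O)c3ccccc3C2=O)Nc2ccccc2I)cc1` carries 2-iodophenyl, and in this assay compound 2 gives 49400 nM. Compound 3 `Cc1ccc(S(=O)(=O)/N=C(/CCNC2=CC(=O)c3ccccc3C2=O)Nc2cccc(C(F)(F)F)c2)cc1` carries 3-(trifluoromethyl)phenyl, and in this assay compound 3 gives 91500 nM, the highest of the three numbers, though both companions sit within the scatter of it: a 1.4-fold higher number from compound 1 to compound 3 (0.15 log units; within the scatter) and a 1.9-fold higher number from compound 2 to compound 3 (0.27 log units; within the scatter).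

Compound 4 `COc1ccc(N/C(CCNC2=CC(=O)c3ccccc3C2=O)=N\S(=O)(=O)c2ccc(C)cc2)c(OC)c1` is the next variation at the same position: 2,4-dimethoxyphenyl in place of 3-(trifluoromethyl)phenyl on an amine nitrogen. Every measured step in the series is of this kind, an exchange of one aryl group for another on the amine nitrogen, and the remaining one is equally flat, a 1.3-fold lower number from compound 1 to compound 2 (0.12 log units; within the scatter). Among the measured compounds shown here, no measured pair separates a methoxy-bearing aryl from a halogen- or trifluoromethyl-bearing one, so the expectation rests on the uniform flatness of these three steps. The step from compound 3 to compound 4 in this assay is therefore expected to stay inside the scatter, a 1.1-fold lower number from compound 3 to compound 4 (0.06 log units; within the scatter), with no direction preferred. For compound 4 the estimate in this assay is 80000 nM, with a range from 40000 nM to 160000 nM.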

Compound 4, half-maximal inhibitory concentration: 83000 nM
Beside the measured number, compound 4's estimate is 1.0-fold (0.02 log units) below it, within the range that was stated.
By their numbers in this assay, from the lowest: compounds 2, 1, 4 and 3 (each within the scatter of the next).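

Aryl exchange on the amine nitrogen: working notes

Compound 4 brings the first methoxy-bearing aryl group into the series, and the exchange replaces a group with 0 hydrogen-bond acceptors by one with 2. In this assay, this leaves the number inside the scatter on every comparison: a 1.1-fold lower number from compound 3 to compound 4 (0.04 log units; within the scatter), a 1.3-fold higher number from compound 1 to compound 4 (0.10 log units; within the scatter) and a 1.7-fold higher number from compound 2 to compound 4 (0.23 log units; within the scatter). The flatness seen among the halogen- and trifluoromethyl-bearing aryl groups therefore extends to 2,4-dimethoxyphenyl, and the four compounds cannot be ordered at this position, while nothing available explains this insensitivity.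

All four groups at this position are substituted phenyl rings carrying neutral substituents, so the compounds shown leave open whether a carboxylic acid or a dialkylamine on the ring, or a pyridine ring in place of the phenyl ring, would move the number beyond the scatter. They also leave open whether the same flatness would hold with a longer chain between the amine nitrogen and the aryl group, or with a simple alkyl group in place of the aryl group.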